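The source may hold more compounds than are shown below. What is called first, only, known or untested is meant among the compounds shown, and "the series" means these compounds.

Measured so far:
compound 1 `C=CS(=O)(=O)c1cc(C(F)(F)F)cc(C(F)(F)F)c1` — < 0.017 h
compound 2 `C=Cc1cc(C(F)(F)F)cc(C(F)(F)F)c1` — > 50 h

Notes on the series. In an ADME assay for pharmacokinetics, read by LC-MS, in phosphate buffer, with a stated time of 72 h, at pH 7.4, tested at 250 uM (on this read-out higher numbers stand for a longer-lived compound and lower numbers for a shorter-lived compound), compound 1 gives < 0.017 h, and this figure is a limit of the assay rather than a number (the limit of < 0.017 h in this assay, at which 1 of the 2 values shown sits). Compound 2 gives > 50 h in this assay, which is again a limit, not a number (the limit of > 50 h in this assay, at which 1 of the 2 values shown sits). Between the two shown compounds, the one measured step runs an at least 2900-fold higher number from compound 1 to compound 2 (3.46 log units; beyond the scatter), vinyl in place of vinylsulfonyl on an aromatic carbon. Compound 2 therefore sits at the upper limit, with no other value in the same region.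

Compound 3 `Fc1cc(C(F)(F)F)cc(C(F)(F)F)c1` differs from compound 2 by fluoro in place of vinyl on an aromatic carbon. For the measured compounds named here, no measured step covers the exchange of vinyl for fluoro. Going by the values given here, the single measured step concerns the removal of the vinylsulfonyl, and it gives no direction for a change that leaves the vinyl behind. On that basis no step beyond the scatter is expected, and compound 3 is estimated to remain at or near the upper limit, with a number no higher from compound 2 to compound 3 (the limit leaves the size open). The half-life of compound 3 is thus estimated at 50 h, within 20 h to 200 h.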

Compound 3, half-life: > 50 h
Compound 3 gave a limit, no number (the forecaster's own chance of this, stated with the estimate: 80%); the middle value lies on the limit itself.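

In this assay, the long half-life does not depend on the vinyl group: compound 3, with fluoro on the same aromatic carbon, gives > 50 h, which is a limit of the assay. Fluoro in place of vinylsulfonyl gives an at least 2900-fold higher number from compound 1 to compound 3 (3.46 log units; beyond the scatter), so a second, quite different replacement now stands against the vinylsulfonyl compound. The step between the vinyl and fluoro compounds cannot be read, and no order between them can be given: the limit of > 50 h in this assay, at which 2 of the 3 values shown sit.

The compounds shown leave open whether the sulfonyl alone or the sulfonyl with its double bond goes with the short half-life, a question that an ethylsulfonyl group on this carbon would address. Going by these compounds, how an amine or a carboxylic acid on this carbon would read in this assay also stays open.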